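The source may report more compounds than this note shows. Statements on the series, on what has been measured and on what is new or still open speak of the compounds shown alone.

Measured so far in an assay on isolated protein for inhibition of mitogen-activated protein kinase kinase kinase 9 (Homo sapiens), tested at 1 uM; a higher number here means more inhibition at the concentration tested (going by the name of the read-out), a lower number less inhibition:
compound 1 `O=C1NCc2c1c1c(c3c2c2ccccc2n3CCO)CCc2cc(OCc3ccccn3)ccc2-1` gives 36% in this assay
compound 2 `O=C1NCc2c1c1c(c3c2c2ccccc2n3CCO)CCc2cc(OCCOCc3ccccc3)ccc2-1` gives 9% in this assay
compound 3 `COCCOc1ccc2c(c1)CCc1c-2c2c(c3c4ccccc4n(CCO)c13)CNC2=O` gives 52% in this assay

Compound 3 stands highest of the three numbers in this assay: a number 16 percentage points higher from compound 1 to compound 3 (beyond the scatter) and a number 43 percentage points higher from compound 2 to compound 3 (beyond the scatter), both beyond the scatter. The third step runs the other way, a number 27 percentage points lower from compound 1 to compound 2 (beyond the scatter). All three steps change only the group on the saturated chain carbon bound to the aromatic oxygen; none removes that chain.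

Compound 4 `O=C1NCc2c1c1c(c3c2c2ccccc2n3CCO)CCc2ccccc2-1` differs from compound 3 in one place: hydrogen in place of 2-methoxyethoxy on an aromatic carbon. For the measured compounds named here, no measured step bears on this change directly. What the measured steps do show is that the read-out in this assay moves, modestly to largely, when the group on this chain is varied, so the aromatic carbon in question is a position where changes register. Going by the values given here, whether the loss of the whole 2-methoxyethoxy lowers or raises the number cannot be read from the three compounds; the working expectation is a downward step, since compound 3 holds the highest number and every variation at this position so far has landed below it. The expected step is a number 22 percentage points lower from compound 3 to compound 4 (beyond the scatter). For compound 4 the estimate in this assay is 30%, with a range from 5% to 55%.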

Compound 4, a percentage reported as inhibition, at one concentration (the size of the read-out at that concentration, not a potency): 14%
Compound 4: middle estimate off by 16 percentage points, on the high side; the measured number falls inside the stated range.
By their numbers in this assay, from the lowest: compounds 2 and 4 (each within the scatter of the next); then compound 1; then compound 3.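

For the compounds shown here, with the substituent on this aromatic carbon replaced by hydrogen, the comparison in this assay gains a baseline that the earlier compounds lacked: a number 38 percentage points lower from compound 3 to compound 4 (beyond the scatter), and a number 22 percentage points lower from compound 1 to compound 4 (beyond the scatter), so 2-methoxyethoxy and (pyridin-2-yl)methoxy each carry a higher number than hydrogen at this position. Having a group here does not by itself raise the number, however, as compound 2 goes against that reading: a number 5 percentage points higher from compound 2 to compound 4 (within the scatter), which leaves 2-(benzyloxy)ethoxy no different from hydrogen in this read-out and makes the outcome depend on which group sits on this carbon. The data at hand offer no explanation for these differences.

On these data alone, it remains open whether a plain methoxy, a longer polyether chain, or a chain ending in an amine or a carboxylic acid would stand with compound 3 or with compound 4 in this assay. Also open, as far as these compounds go, is how these numbers at one concentration would translate into potency, and whether the same order of groups would hold on another carbon of this ring.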